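The source may hold more compounds than are shown below. What is called first, only, known or untested is meant among the compounds shown, and "the series" means these compounds.

Measured compounds:
- compound 1 `O=C(Nc1ccc(Oc2ccnc3[nH]ccc23)c(F)c1)c1nn(-c2ccc(Br)cc2)ccc1=O`: in a functional assay on PC-3 cells (Homo sapiens) for cytotoxicity, read by MTT assay, with a stated time of 72 h (on this read-out higher numbers stand for weaker inhibition and lower numbers for stronger inhibition), compound 1 gives 40800 nM
- compound 2 `O=C(Nc1ccc(Oc2ccnc3[nH]ccc23)c(F)c1)c1nn(-c2ccccc2)ccc1=O`: in this assay compound 2 gives 38600 nM
- compound 3 `Cn1ccc2c(Oc3ccc(NC(=O)c4nn(-c5ccc(Br)cc5)ccc4=O)cc3)ccnc21`: in this assay compound 3 gives 23000 nM

Compound 1 and compound 2 share a core and differ in one place, (hydrogen in place of bromo on an aromatic carbon); this gave a 1.1-fold lower number from compound 1 to compound 2 (0.02 log units; within the scatter). Compound 3 rests on a different core, and the difference between the two cores is not broken down here. The unmeasured compound 4 `Cn1ccc2c(Oc3ccc(NC(=O)c4nn(-c5ccccc5)ccc4=O)cc3)ccnc21` differs from compound 3 by the same change, (hydrogen in place of bromo on an aromatic carbon), at the same place. Because the earlier step of a 1.1-fold lower number from compound 1 to compound 2 (0.02 log units; within the scatter) was small, a step of similar size is expected from compound 3 to compound 4 in this assay, namely a 1.1-fold lower number from compound 3 to compound 4 (0.04 log units; within the scatter). Compound 4 is therefore estimated at 21000 nM, likely between 10000 nM and 45000 nM.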

Compound 4, half-maximal inhibitory concentration: 58200 nM
Compound 4: middle estimate off by 2.8-fold (0.44 log units), on the low side, outside the stated range (above it).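

In this assay, putting hydrogen in place of bromo on the core of compound 3 gave a 2.5-fold higher number from compound 3 to compound 4 (0.40 log units; beyond the scatter), so on this core the phenyl compound inhibits less strongly than the 4-bromophenyl compound. The same change therefore did not carry over with the same size from one core to the other: the same change on two cores in this assay, a 1.1-fold lower number (0.02 log units; within the scatter) from compound 1 to compound 2 and a 2.5-fold higher number (0.40 log units; beyond the scatter) from compound 3 to compound 4, 2.7-fold (0.43 log units) apart, beyond the scatter of two such steps This shows that the effect of the change depends on the core in these two pairs, but it does not show which difference between the cores is responsible, or how the change would behave on a third core.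

The compounds shown leave open how a different group at this place, such as chloro, methoxy or an amine, would behave on either core. They also leave open whether the same gap between the two steps would appear in other cell types.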